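Aryl substituent removal in the tetrabromo series

The source may hold more compounds than are shown below. What is called first, only, known or untested is meant among the compounds shown, and "the series" means these compounds.

Measured so far in a functional assay on MCF7 cells (Homo sapiens) for antiproliferative activity, read by MTT assay, with a stated time of 24 h, tested at 50 uM; on this read-out lower numbers stand for a stronger effect and higher numbers for a weaker effect at the one concentration tested: compound 1 `OC(CCn1nc2c(Br)c(Br)c(Br)c(Br)c2n1)c1ccc(F)cc1` gives 16%; compound 2 `COc1cccc(C(O)CCn2nc3c(Br)c(Br)c(Br)c(Br)c3n2)c1` gives 22%; compound 3 `OC(CCn1nc2c(Br)c(Br)c(Br)c(Br)c2n1)c1cccc(Cl)c1` gives 28%.

Compound 3 holds the highest of the three numbers in this assay; a number 6 percentage points higher from compound 2 to compound 3 (within the scatter), whereas a number 12 percentage points higher from compound 1 to compound 3 (beyond the scatter).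

Compound 4 `OC(CCn1nc2c(Br)c(Br)c(Br)c(Br)c2n1)c1ccccc1` differs from compound 3 in one place: hydrogen in place of chloro on an aromatic carbon. Going by the values given here, the steps that bear on this change are those altering the substituent on the same ring: a number 6 percentage points higher from compound 1 to compound 2 (within the scatter) and a number 6 percentage points higher from compound 2 to compound 3 (within the scatter), both within the scatter, and a number 12 percentage points higher from compound 1 to compound 3 (beyond the scatter), the only one beyond it. Changes on this ring have thus shifted the read-out little. For compound 4 no more than a small step toward lower numbers is expected, a number 6 percentage points lower from compound 3 to compound 4 (within the scatter). Compound 4 is estimated at 22%, within 12% to 32%.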

Compound 4, a percentage reported as activity, at one concentration (the size of the read-out at that concentration, not a potency): 28%
The estimate for compound 4 lay 6 percentage points below the measured number; measured number inside the range.
By their numbers in this assay, from the lowest: compounds 1, 2, 3 and 4 (each within the scatter of the next, the first and the last beyond it).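

In this assay, taking the substituent off entirely leaves the read-out unmoved (no change at the digits printed from compound 3 to compound 4 (within the scatter)). The bare phenyl also stays level with the methoxy compound (a number 6 percentage points higher from compound 2 to compound 4 (within the scatter)), while the fluoro compound alone stands apart (a number 12 percentage points higher from compound 1 to compound 4 (beyond the scatter)), so among these four compounds only the 4-fluorophenyl separates from the phenyl beyond the scatter. No measurement on hand gives a reason for this.

The compounds shown do not separate the fluoro group from its ring place. From the compounds shown here alone, an amine or a carboxylic acid on this ring remains open.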